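Extending compound 3 to compound 4

A few compounds are considered here, and "the series" means these few. Any claim that something is new, unique, unknown or untested is made for them only; others in the source may bear on it.

Measured in a physicochemical assay for lipophilicity, read by HPLC; a lower number here means a more polar compound, a higher number a more lipophilic compound:
- compound 1 `CC(C)(C)c1ccccc1Oc1ncccc1NC(=O)Nc1ccc(C2(CO)CC2)cc1` gives 4.6
- compound 2 `CC(C)(C)c1ccccc1Oc1ncccc1NC(=O)Nc1ccc(-c2ccccc2CO)cc1F` gives 5.5
- compound 3 `CN(C)Cc1ccc(NC(=O)Nc2cccnc2Oc2ccccc2C(C)(C)C)c(F)c1` gives 4.2

Of these three, compound 3 stands lowest at 4.2. Above it, compound 1 lies nearest at 4.6 and compound 2 furthest at 5.5, both gaps beyond the scatter.

Compound 4 `CN(C)Cc1cccc(-c2ccc(NC(=O)Nc3cccnc3Oc3ccccc3C(C)(C)C)c(F)c2)c1` has not yet been measured. In it, 3-((dimethylamino)methyl)phenyl stands in place of (dimethylamino)methyl on an aromatic carbon, meta to a fluoro group (3-((dimethylamino)methyl)phenyl in place of (dimethylamino)methyl on an aromatic carbon).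

Among the compounds with values here, one measured step bears on this change: a number 1.30 log units lower from compound 2 to compound 3 (beyond the scatter), a large step beyond the scatter, with (dimethylamino)methyl in place of 2-(hydroxymethyl)phenyl. The new change runs broadly the other way, putting a phenyl ring back, so a large rise of similar size is expected in this assay. Within the data shown here, no measured compound shows what the different group on that ring does to the number. The expected step is a number 1.20 log units higher from compound 3 to compound 4 (beyond the scatter). Compound 4 is estimated at 5.4, with an expected range of 4.9 to 5.9.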

Compound 4, partition coefficient: 5.5
Compound 4: middle estimate off by 0.10 log units, on the low side; low and high end bracket the measured number.
By their numbers in this assay, from the lowest: compound 3; then compound 1; then compounds 2 and 4 (each within the scatter of the next).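

In this assay, the change gives a number 1.30 log units higher from compound 3 to compound 4 (beyond the scatter): here the (dimethylamino)methyl group stays in the molecule and a six-membered aromatic ring of carbon only is added, a change that the earlier step, which swapped the whole group, did not isolate. The other new comparison gives no change at the digits printed from compound 2 to compound 4 (within the scatter), so at this position 3-((dimethylamino)methyl)phenyl and 2-(hydroxymethyl)phenyl are not told apart by this assay, although they differ in the group the ring carries and in where it carries it. No measurement is available that explains either result.

Compounds 2 and 4 cannot show how much of that match comes from the identity of the group and how much from its place on the ring. Also open, on these data alone, is how the number would respond to a plain phenyl, or to a morpholine or a carboxylic acid on that ring.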